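The source may hold more compounds than are shown below. What is called first, only, known or untested is meant among the compounds shown, and "the series" means these compounds.

In a functional assay on HT-29 cells (Homo sapiens) for inhibition, read by sulforhodamine B assay, with a stated time of 48 h (a lower number here means a stronger inhibitor of growth, a higher number a weaker inhibitor of growth), compound 1 `Cc1ccc(C2=NN(c3ccc(S(C)(=O)=O)cc3)C(=O)CC2)cc1` gives 10000 nM, while compound 2 `Cc1cc(O)ccc1C1=NN(c2ccc(S(C)(=O)=O)cc2)C(=O)CC1` gives 32300 nM, the higher of the two numbers. Compound 3 `CCc1ccc(C2=NN(c3ccc(S(C)(=O)=O)cc3)C(=O)CC2)cc1` is the next structure, and it has 4-ethylphenyl in place of 4-hydroxy-2-methylphenyl on a carbon with a double bond to nitrogen. For the measured compounds named here, the one measured step that bears on this is a 3.2-fold higher number from compound 1 to compound 2 (0.51 log units; beyond the scatter), which is modest and beyond the scatter. Compound 3 loses the group that step introduced and, like compound 1 at 10000 nM, has a 4-alkylphenyl group, so a similar step back towards a lower number is expected in this assay. The estimated step is a 2.9-fold lower number from compound 2 to compound 3 (0.47 log units; beyond the scatter). For compound 3 the expected value is 11000 nM, with an estimated range of 4500 nM to 28000 nM.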

Compound 3, concentration for total growth inhibition: 12100 nM
Compound 3: the middle estimate sits 1.1-fold (0.04 log units) below what was measured, within the range that was stated.
By their numbers in this assay, from the lowest: compounds 1 and 3 (each within the scatter of the next); then compound 2.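

In this assay, the 4-ethylphenyl group gives a 2.7-fold lower number from compound 2 to compound 3 (0.43 log units; beyond the scatter), which shows that a second alkyl group at this position also sits apart from the 4-hydroxy-2-methylphenyl compound. Methyl in place of hydrogen on the saturated chain carbon gives a 1.2-fold higher number from compound 1 to compound 3 (0.08 log units; within the scatter), so compound 1 and compound 3 cannot be told apart here. Nothing given explains these numbers. The compounds shown leave open whether the hydroxyl or the ring methyl of compound 2 sets its number apart. From the compounds shown here alone, how a longer chain or an amine would read at this position also remains open.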